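The source may report more compounds than this note shows. Statements on the series, on what has been measured and on what is new or still open speak of the compounds shown alone.

Measured compounds and their numbers:

Compound 1 `CC(=O)NS(=O)(=O)c1ccc(N/C(S)=N\c2ccnc3cc(C(F)(F)F)ccc23)cc1` gives 37600 nM in a functional assay on HeLa cells (Homo sapiens) for antiproliferative activity, read by sulforhodamine B assay, with a stated time of 48 h; a lower number here means a stronger inhibitor, a higher number a weaker inhibitor.
Compound 2 `O=S(=O)(Nc1nccs1)c1ccc(N/C(S)=N\c2ccnc3cc(C(F)(F)F)ccc23)cc1` gives 95200 nM in this assay.
Compound 3 `Cc1ccnc(NS(=O)(=O)c2ccc(N/C(S)=N\c3ccnc4cc(C(F)(F)F)ccc34)cc2)n1` gives 31000 nM in this assay.

All three share one core and differ only in the group carried on the sulfonamide nitrogen. Compound 3 has the lowest number of the three, but its distance to compound 1 is small: a 1.2-fold lower number from compound 1 to compound 3 (0.08 log units; within the scatter). The step from compound 2 is larger: a 3.1-fold lower number from compound 2 to compound 3 (0.49 log units; beyond the scatter). The exchange from compound 1 to compound 2 went the other way: a 2.5-fold higher number from compound 1 to compound 2 (0.40 log units; beyond the scatter). Taken together, swapping the group on the sulfonamide nitrogen has so far moved the number only modestly in either direction.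

Compound 4 `COc1cc(NS(=O)(=O)c2ccc(N/C(S)=N\c3ccnc4cc(C(F)(F)F)ccc34)cc2)nc(OC)n1` is not yet measured. It differs from compound 3 in one place: 2,6-dimethoxypyrimidin-4-yl in place of 4-methylpyrimidin-2-yl on a sulfonamide nitrogen. For the measured compounds named here, no measured step involves this exact exchange; the nearest guidance is that one aromatic group replacing another on this nitrogen, as in the step from compound 2 to compound 3, changed the number modestly. The expectation for compound 4 is therefore a small step, perhaps none beyond the scatter, in this assay: a 1.0-fold lower number from compound 3 to compound 4 (0.01 log units; within the scatter). Compound 4 is estimated at 30000 nM, with a likely range from 12000 nM to 75000 nM.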

Compound 4, half-maximal inhibitory concentration: 53800 nM
Estimate against measurement, compound 4: 1.8-fold (0.25 log units) below; measured number inside the range.
By their numbers in this assay, from the lowest: compounds 3, 1, 4 and 2 (each within the scatter of the next, the first and the last beyond it).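

In this assay, the 2,6-dimethoxypyrimidin-4-yl group has more heavy atoms and more hydrogen-bond acceptors than 4-methylpyrimidin-2-yl, yet this exchange on the sulfonamide nitrogen stays within the scatter (a 1.7-fold higher number from compound 3 to compound 4 (0.24 log units; within the scatter)). Compound 4 also cannot be told apart from the compounds carrying 1,3-thiazol-2-yl (a 1.8-fold lower number from compound 2 to compound 4 (0.25 log units; within the scatter)) or acetyl (a 1.4-fold higher number from compound 1 to compound 4 (0.16 log units; within the scatter)) on this nitrogen, so it sits within the scatter of all three earlier compounds, even though compound 2 remains beyond the scatter from both compound 1 and compound 3. No measurement shown here explains why these groups give such similar numbers.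

Left open is whether a different kind of group on this nitrogen, such as a simple methyl, a longer alkyl chain or a phenyl ring bearing a carboxylic acid, would keep the number in this same range or move it well away. Every compound shown also keeps the shared core unchanged, and what a change there would do to the number stays open.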